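The compounds below may be only part of what the source reports. "The series", "measured", "known", "first", "only" and "open" are said of these compounds alone.

Compound 2 `Cc1ccc(NC(=S)NC(=O)c2ccc(OCc3cccc(Cl)c3Cl)cc2)cc1-c1nc2ccccc2[nH]1` reached only a limit in a functional assay on MNK45 cells (Homo sapiens) for inhibition, read by MTT assay, with a stated time of 48 h; on this read-out higher numbers stand for weaker inhibition and lower numbers for stronger inhibition: compound 2 gives > 100000 nM, which is a limit of the assay rather than a number (the limit of > 100000 nM in this assay, at which 1 of the 2 values shown sits). Compound 1 `Cc1ccc(NC(=S)NC(=O)c2ccc(OCc3cccc(Cl)c3)cc2)cc1-c1nc2ccccc2[nH]1`, which carries one chlorine fewer, gives 43300 nM in this assay, and the step of an at least 2.3-fold higher number from compound 1 to compound 2 (0.36 log units; beyond the scatter) shows that the added chlorine went with weaker inhibition. Compound 3 `Cc1ccc(NC(=S)NC(=O)c2ccc(OCc3cccc(F)c3)cc2)cc1-c1nc2ccccc2[nH]1` differs from compound 2 by 3-fluorophenyl in place of 2,3-dichlorophenyl on a saturated chain carbon bound to an oxygen on an aromatic ring. Since that change removes the chlorines again, the step of an at least 2.0-fold lower number from compound 2 to compound 3 (0.30 log units; that floor lies within the scatter) is expected to run the other way, toward stronger inhibition. Compound 3 is therefore estimated at 50000 nM, between 20000 nM and 120000 nM.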

Compound 3, half-maximal inhibitory concentration: 86800 nM
Beside the measured number, compound 3's estimate is 1.7-fold (0.24 log units) below it; measured number inside the range.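

In this assay, fluoro in place of chloro on this ring gives a 2.0-fold higher number from compound 1 to compound 3 (0.30 log units; within the scatter), so fluoro and chloro cannot be told apart here. Removing both chlorines and adding fluoro gives an at least 1.1-fold lower number from compound 2 to compound 3 (0.06 log units; that floor lies within the scatter), which sets only a floor on that change. Compound 2 stands at a limit, not a number: the limit of > 100000 nM in this assay, at which 1 of the 3 values shown sits.

On these data alone, all three compounds carry halogen on this ring, so the effect of a ring without halogen remains open. A methoxy group, an amine or a carboxylic acid in this place could show whether inhibition here can become stronger.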